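The compounds below may be only part of what the source reports. "The series", "measured", "known", "first", "only" and "open" are said of these compounds alone.

Compound 1 `CC1(/C=C/c2ccc(C(F)(F)F)cc2)C=CC(=O)O1` gives 34000 nM
Compound 2 `COc1ccc(/C=C/C2(C)C=CC(=O)O2)cc1OC` gives 22900 nM

In a functional assay on 786-0 cells (Homo sapiens) for inhibition, read by sulforhodamine B assay, with a stated time of 48 h (a lower number here means a stronger inhibitor of growth, a higher number a weaker inhibitor of growth), compound 2 gives 22900 nM and lies within the usual scatter of compound 1 , so the two numbers cannot be ranked against each other.

The next compound to be tested is compound 3 `COc1ccc(/C=C/C2(C)C=CC(=O)O2)cc1`. It differs from compound 2 in a single place: hydrogen in place of methoxy on an aromatic carbon. This is hydrogen in place of methoxy on an aromatic carbon, ortho to a methoxy group.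

Among the compounds with values here, no two measured compounds differ in only one place, so no measured step shows directly what this change does. Within the data shown here, the only guide is a loose one: compound 1 at 34000 nM and compound 2 at 22900 nM carry different groups, yet their values stay within the scatter of each other. A change in either direction beyond the scatter is therefore not expected here.

The expected change is a 1.1-fold higher number from compound 2 to compound 3 (0.04 log units; within the scatter), a step estimated to stay within the scatter. For compound 3 the estimated value is 25000 nM, with an expected range from 12000 nM to 50000 nM as the likely span.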

Compound 3, concentration for total growth inhibition: > 1000000 nM
Compound 3 gave a limit, no number; the forecaster's own chance of this, stated with the estimate: 10%; at least 40-fold (1.60 log units) between middle value and limit.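

In this assay compound 3 gives > 1000000 nM, which is a limit of the assay and not a number. The earlier pair gave no sign that this ring position mattered, yet hydrogen in place of methoxy, ortho to a methoxy group, comes with an at least 43-fold higher number from compound 2 to compound 3 (1.64 log units; beyond the scatter), so the methoxy at this place cannot be dropped without a large loss of growth inhibition in this assay. Methoxy in place of trifluoromethyl on an aromatic carbon comes with an at least 29-fold higher number from compound 1 to compound 3 (1.46 log units; beyond the scatter), so a ring with the single methoxy of compound 3 does not match the ring of compound 1 either, even though compound 1 has no methoxy at all.

From the compounds shown here alone, both steps are lower bounds, and how far compound 3 really lies from the other two stays open: the limit of > 1000000 nM in this assay, at which 1 of the 3 values shown sits. Also open is whether the gain at this position needs a methoxy specifically, or whether a hydroxyl, a fluorine or an amine at the same aromatic carbon would serve as well.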